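The compounds below may be only part of what the source reports. "The series", "measured", "known", "first", "only" and "open" are said of these compounds alone.

Measured so far:
compound 1 `C=CC[n+]1cn(C)c2nc[nH]/c(=N\OC)c21`: > 80000 nM
compound 2 `CO/N=c1\[nH]cnc2c1[n+](C/C=C(\C)CC/C=C(\C)CC/C=C(\C)CCC=C(C)C)cn2C(c1ccccc1)c1ccccc1`: 2600 nM
compound 3 `CC(C)=CCC/C(C)=C/CC/C(C)=C/CC/C(C)=C/Cn1cnc2c1C(=N)NCN2C`: 18200 nM

In a functional assay on cells (Homo sapiens) for cytotoxicity (a lower number here means a stronger inhibitor, a higher number a weaker inhibitor), compound 3 gives 18200 nM, the higher of the two numbers in the series. For compound 1 the entry > 80000 nM is a limit of the assay, not a number (the limit of > 80000 nM in this assay, at which 1 of the 3 values shown sits). Compound 2 gives 2600 nM, and its distance to compound 3 lies beyond the scatter.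

Compound 4 `CC(C)=CCC/C(C)=C/CC/C(C)=C/CC/C(C)=C/Cn1cnc2c1C(=N)N(C)CN2C` differs from compound 3 by methyl in place of hydrogen on an amine nitrogen in a ring. Among the measured compounds shown here, no measured step of this kind exists, so the expectation rests on the small size of the change alone. In this assay compound 4 is expected to give about 15000 nM, within 5000 nM to 50000 nM. The step of a 1.2-fold lower number from compound 3 to compound 4 (0.08 log units; within the scatter) is thus expected to stay within the scatter, in no clear direction.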

Compound 4, half-maximal inhibitory concentration: 2510 nM
The estimate for compound 4 lay 6.0-fold (0.78 log units) above the measured number, and the stated range ends above it.
By their numbers in this assay, from the lowest: compounds 4 and 2 (each within the scatter of the next); then compound 3. At a limit, above all of these: compound 1.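

The change of methyl in place of hydrogen on an amine nitrogen in a ring gives a 7.3-fold lower number from compound 3 to compound 4 (0.86 log units; beyond the scatter) in this assay and so is not a silent one. This ring nitrogen is therefore a position where a small group alone moves the number beyond the scatter. Nothing available here accounts for the size of this step.

On these data alone, whether the step is particular to methyl remains open, and an ethyl or acetyl group on the same nitrogen would address this. Also open, as far as these compounds go, is whether the same change has a similar effect with a shorter chain in place of the long unsaturated one.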